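The source may hold more compounds than are shown below. What is called first, only, known or untested is meant among the compounds shown, and "the series" means these compounds.

In an assay on COS-7 cells for inhibition of sodium/nucleoside cotransporter 2 (Homo sapiens), read by scintillation counting, in the presence of a further agent that is not named here (a lower number here means a stronger inhibitor, a higher number a weaker inhibitor), two compounds have been measured:
compound 1 `Cc1cccc(CNc2nc3c(N)ncnc3n2[C@@H]2O[C@H](CO)[C@@H](O)[C@H]2O)c1` gives 19000 nM
compound 2 `Nc1ncnc2c1nc(NCc1ccc3ccccc3c1)n2[C@@H]1O[C@H](CO)[C@@H](O)[C@H]1O` gives 5300 nM

Going by the values given here, compound 2 stands lowest of these two numbers; its only neighbour is compound 1, separated by a 3.6-fold lower number from compound 1 to compound 2 (0.55 log units; beyond the scatter). Compound 3 `Nc1ncnc2c1nc(NCc1cccc3ccccc13)n2[C@@H]1O[C@H](CO)[C@@H](O)[C@H]1O` differs from compound 2 in one place: naphthalen-1-yl in place of naphthalen-2-yl on a saturated chain carbon bound to a nitrogen on an aromatic ring. No measured step compares the two naphthyl attachments, and the one step shown, a 3.6-fold lower number from compound 1 to compound 2 (0.55 log units; beyond the scatter), concerns a different exchange, so it gives no direction here. Compound 3 is therefore expected to show no step beyond the scatter, a 1.2-fold higher number from compound 2 to compound 3 (0.09 log units; within the scatter). The estimate for compound 3 is 6500 nM, within 2000 nM to 20000 nM.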

Compound 3, half-maximal inhibitory concentration: 5700 nM
For compound 3 the middle estimate is 1.1-fold (0.06 log units) above the measured one; the measured number falls inside the stated range.
By their numbers in this assay, from the lowest: compounds 2 and 3 (each within the scatter of the next); then compound 1.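

In this assay, exchanging naphthalen-2-yl for naphthalen-1-yl on the saturated chain carbon makes no difference beyond the scatter, with a 1.1-fold higher number from compound 2 to compound 3 (0.03 log units; within the scatter) between them. The advantage over 3-methylphenyl therefore does not depend on which naphthyl attachment is present, as a 3.3-fold lower number from compound 1 to compound 3 (0.52 log units; beyond the scatter) stands beside the earlier step of a 3.6-fold lower number from compound 1 to compound 2 (0.55 log units; beyond the scatter) in size. Still open, going by these compounds, is how a longer chain between the nitrogen and the naphthyl group, or a carboxylic acid or an amine on the naphthyl rings, would read here. Nothing at hand explains why the two attachments read alike.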